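A Fluorinated Ether Change Carried to a Second Compound

The source may hold more compounds than are shown below. What is called first, only, known or untested is meant among the compounds shown, and "the series" means these compounds.

Measured so far:
Compound 1 `CCN(Cc1nc2cc(C(F)(F)F)ccc2nc1-c1ccccc1)c1ccc(OC)cc1` gives 7000 nM
Compound 2 `CCN(Cc1nc2cc(C(F)(F)F)ccc2nc1-c1ccccc1)c1ccc(OC(F)(F)F)cc1` gives 5000 nM
Compound 3 `C#CCN(Cc1nc2cc(C(F)(F)F)ccc2nc1-c1ccccc1)c1ccc(OC)cc1` gives 3000 nM

These three numbers come from an assay on isolated protein for inhibition of Dihydrofolate reductase (Homo sapiens), read by spectrophotometry; a lower number here means a stronger inhibitor, a higher number a weaker inhibitor. Compound 2 differs from compound 1 by trifluoromethyl in place of methyl on an oxygen on an aromatic ring, and the outcome was a 1.4-fold lower number from compound 1 to compound 2 (0.15 log units; within the scatter). Compound 3 differs from compound 1 by ethynyl in place of methyl on a saturated chain carbon bound to a nitrogen on an aromatic ring, and here the outcome was a 2.3-fold lower number from compound 1 to compound 3 (0.37 log units; beyond the scatter).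

Compound 4 `C#CCN(Cc1nc2cc(C(F)(F)F)ccc2nc1-c1ccccc1)c1ccc(OC(F)(F)F)cc1` has not been measured yet. It differs from compound 3 by trifluoromethyl in place of methyl on an oxygen on an aromatic ring, which is the same change that separates compound 2 from compound 1, made at the same place on the same kind of ring. Going by the values given here, only that one earlier pair shows what this change does, and there it stayed within the usual scatter. A step of about a 1.4-fold lower number from compound 3 to compound 4 (0.13 log units; within the scatter) in this assay is therefore expected for compound 4, because a 1.4-fold lower number from compound 1 to compound 2 (0.15 log units; within the scatter) was small. For compound 4 the estimate in this assay is 2200 nM, with a likely range from 1000 nM to 5000 nM.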

Compound 4, inhibition constant: 4000 nM
For compound 4 the middle estimate is 1.8-fold (0.26 log units) below the measured one; measured number inside the range.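

In this assay, trifluoromethyl in place of methyl on the oxygen now gives a 1.3-fold higher number from compound 3 to compound 4 (0.12 log units; within the scatter), while ethynyl in place of methyl gives a 1.3-fold lower number from compound 2 to compound 4 (0.10 log units; within the scatter). The trifluoromethyl change cannot be told apart on the two cores, and both of its steps are too small to give it a direction: the same change on two cores in this assay, a 1.4-fold lower number (0.15 log units; within the scatter) from compound 1 to compound 2 and a 1.3-fold higher number (0.12 log units; within the scatter) from compound 3 to compound 4, 1.9-fold (0.27 log units) apart, within the scatter of two such steps The ethynyl change also shows no measurable dependence on the core, yet two pairs do not prove that it carries over unchanged, and its step is beyond the scatter on only one of the two cores: the same change on two cores in this assay, a 2.3-fold lower number (0.37 log units; beyond the scatter) from compound 1 to compound 3 and a 1.3-fold lower number (0.10 log units; within the scatter) from compound 2 to compound 4, 1.9-fold (0.27 log units) apart, within the scatter of two such steps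

The compounds shown carry only methoxy or trifluoromethoxy on the aromatic ring, so an amine or a carboxylic acid at that place remains untested here. A longer chain in place of the ethynyl is open as well, as is whether either change would behave the same way on a third core.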